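Replacing the piperidin-1-yl group of compound 2

The compounds below may be only part of what the source reports. "The series", "measured", "known", "first", "only" and "open" are said of these compounds alone.

Measured so far in an ADME assay on microsomes from liver (Homo sapiens) for metabolic stability, with a stated time of 30 min, tested at 1 uM; on this read-out higher numbers stand for a longer-lived compound and lower numbers for a shorter-lived compound
- compound 1 `COc1cccc(CN2C(=O)CN(C(=O)c3cc4cc(OC)ccc4o3)C[C@@H]2CCc2ccccc2)c1` gives 0.128 h
- compound 2 `COc1ccc2[nH]c(C(=O)N3CC(=O)N(Cc4ccccc4)[C@@H](CN4CCCCC4)C3)cc2c1` gives 0.283 h

Of these two numbers, compound 2 stands highest at 0.283 h, and the gap to compound 1 lies beyond the scatter. Compound 3 `COc1ccc2[nH]c(C(=O)N3CC(=O)N(Cc4ccccc4)[C@@H](CN4CC5CCCCC5C4)C3)cc2c1` differs from compound 2 in one place, on a saturated chain carbon bound to a saturated ring carbon, by a group of 9 heavy atoms (8 carbon, 1 nitrogen; one five-membered non-aromatic ring with 1 hetero atom, one six-membered non-aromatic ring of carbon only) in place of a group of 6 heavy atoms (5 carbon, 1 nitrogen; one six-membered non-aromatic ring with 1 hetero atom), on a saturated chain carbon bound to a saturated ring carbon. Among the compounds with values here, no measured pair shows a step of this kind, so the expectation in this assay is only a modest step toward a shorter half-life, possibly none beyond the scatter. The expected change is a 1.6-fold lower number from compound 2 to compound 3 (0.20 log units; within the scatter). For compound 3 the estimated half-life is 0.18 h, with an expected range of 0.09 h to 0.36 h.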

Compound 3, half-life: 0.233 h
Beside the measured number, compound 3's estimate is 1.3-fold (0.11 log units) below it; the range from low to high includes it.
By their numbers in this assay, from the lowest: compounds 1, 3 and 2 (each within the scatter of the next, the first and the last beyond it).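

In this assay, putting the group of 9 heavy atoms, with its five-membered and six-membered non-aromatic rings, in place of piperidin-1-yl gives a 1.2-fold lower number from compound 2 to compound 3 (0.08 log units; within the scatter), a step within the scatter. On a saturated chain carbon bound to a saturated ring carbon, this change therefore leaves the half-life indistinguishable between the two groups. Nothing available bears on a reason for this result. The compounds shown leave open whether a morpholin-4-yl group or an open-chain dimethylamino group at this place would give a step beyond the scatter.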